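A methoxy added to compound 2

The source may report more compounds than this note shows. Statements on the series, on what has been measured and on what is new or still open speak of the compounds shown alone.

Compound 1 `Cc1ccc(-c2oc3ccccc3c(=O)c2C)cc1` gives 102 ug/mL
Compound 2 `Cc1c(-c2ccccc2)oc2ccccc2c1=O` gives 106 ug/mL
Compound 3 `Cc1c(-c2ccccc2Cl)oc2ccccc2c1=O` gives 192 ug/mL

In a functional assay, read by spectrophotometry, with a stated time of 20 min (on this read-out higher numbers stand for weaker inhibition and lower numbers for stronger inhibition), compound 2 gives 106 ug/mL and cannot be told apart from either of the other two compounds. Compound 4 `COc1cccc(-c2oc3ccccc3c(=O)c2C)c1` differs from compound 2 by methoxy in place of hydrogen on an aromatic carbon meta to a large group. Two measured changes on an aromatic carbon bear on this: hydrogen in place of methyl gave a 1.0-fold higher number from compound 1 to compound 2 (0.02 log units; within the scatter) and chloro in place of hydrogen gave a 1.8-fold higher number from compound 2 to compound 3 (0.26 log units; within the scatter) and neither lies beyond the scatter. Among the measured compounds shown here, no methoxy compound has been measured, so no step beyond the scatter is expected in this assay for this change. The expected step is a 1.1-fold higher number from compound 2 to compound 4 (0.05 log units; within the scatter) and it stays within that scatter. Compound 4 is estimated at 120 ug/mL with a range of 55 ug/mL to 260 ug/mL and its measurement is still to come.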

Compound 4, half-maximal inhibitory concentration: 156 ug/mL
Estimate against measurement, compound 4: 1.3-fold (0.11 log units) below; measured number inside the range.
By their numbers in this assay, from the lowest: compounds 1, 2, 4 and 3 (each within the scatter of the next).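

In this assay, methoxy in place of hydrogen on this aromatic carbon, meta to a large group, gives a 1.5-fold higher number from compound 2 to compound 4 (0.17 log units; within the scatter). Among the compounds shown here, this is the first measurement at this position, and it shows that a methoxy group here leaves the number within the scatter, as the methyl and chloro changes elsewhere on an aromatic carbon also did. Nothing available accounts for this result.

On these data alone, whether an amine or a carboxylic acid on this carbon would move the number beyond the scatter remains open. So does whether methoxy on another aromatic carbon would behave the same way.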